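The compounds below may be only part of what the source reports. "The series", "measured", "known", "first", "only" and "open" are said of these compounds alone.

Measured so far:
compound 1, `CN1CCN(c2ccc(C3=NN(S(=O)(=O)c4ccc(F)cc4)C(c4ccc(N(C)C)cc4)C3)cc2)CC1` — 15.7%
compound 2, `CN1CCN(c2ccc(C3=NN(S(=O)(=O)c4ccc(Br)cc4)C(c4ccc(N(C)C)cc4)C3)cc2)CC1` — 23.7%
compound 3, `COC(=O)CC(=O)N1N=C(c2ccc(-n3cncn3)cc2)CC1c1ccc(N(C)C)cc1` — 6.8%

In a functional assay on MDA-MB-231 cells (Homo sapiens) for inhibition, read by sulforhodamine B assay, tested at 10 uM (a higher number here means more inhibition at the concentration tested (going by the name of the read-out), a lower number less inhibition), compound 3 stands lowest of the three numbers; the nearest is compound 1, whose number lies within the scatter of it, and the furthest is compound 2, whose number lies beyond the scatter. Compound 4, `CN(C)c1ccc(C2CC(c3ccc(-n4cncn4)cc3)=NN2S(=O)(=O)c2ccc(C#N)cc2)cc1`, has not been measured. Its difference from compound 3 is the following.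

(4-cyanophenyl)sulfonyl in place of ((methoxycarbonyl)methyl)carbonyl on an amine nitrogen in a ring

Within the data shown here, the only measured step is a number 8 percentage points higher from compound 1 to compound 2 (within the scatter), a change of bromo in place of fluoro on an aromatic carbon. Among the measured compounds shown here, it does not touch the amine nitrogen in a ring and so does not bear directly on the step to compound 4; it shows only that a change on the (4-halophenyl)sulfonyl group left the read-out within the scatter. For the measured compounds named here, compounds 1 and 2 both carry a substituted phenylsulfonyl group on that nitrogen and both give numbers above compound 3, but they differ from compound 3 in more than one place, so no single step is known for the exchange itself. The step of a number 10.2 percentage points higher from compound 3 to compound 4 (beyond the scatter) is therefore expected to be a modest rise, toward the range of compounds 1 and 2, with wide uncertainty. Compound 4 is estimated at 17%, between 4% and 32%.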

Compound 4, a percentage reported as inhibition, at one concentration (the size of the read-out at that concentration, not a potency): 32.8%
Compound 4: the middle estimate sits 15.8 percentage points below what was measured; measured number outside the range, above it.
By their numbers in this assay, from the lowest: compounds 3, 1, 2 and 4 (each within the scatter of the next, the first and the last beyond it).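

In this assay, among these compounds, (4-cyanophenyl)sulfonyl in place of ((methoxycarbonyl)methyl)carbonyl on the amine nitrogen in a ring gives a number 26 percentage points higher from compound 3 to compound 4 (beyond the scatter) as the first single-place step to lie beyond the scatter. Among the compounds shown here, the read-out therefore responds to what this ring nitrogen carries, at least for this exchange, whereas the only earlier step, a number 8 percentage points higher from compound 1 to compound 2 (within the scatter) for bromo in place of fluoro on an aromatic carbon, gave no such evidence. The data at hand offer no measured basis for explaining why this exchange raises the read-out.

The exchange replaces the whole group, so the step cannot be divided between the sulfonyl link, the aromatic ring and the nitrile: a 4-cyanobenzoyl group or a methylsulfonyl group on the same nitrogen would begin to separate these parts. The compounds shown also leave open whether the rise would persist with a plain phenylsulfonyl group, and the read-out at a single concentration gives no potency for any of them.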